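This account rests on a few compounds, and the source may have more. Where it says the series, first, only, none or still open, it means among the compounds named here.

Compound 1 `CN(C)C(=O)c1cc2cnc(Nc3ccc(NC(=O)C4(C(=O)Nc5cccc(Cl)c5)CC4)cc3)nc2n1C1CCCC1` stands lowest of the two numbers measured in a functional assay on SiHa cells (Homo sapiens) for inhibition, read by CCK-8 assay, with a stated time of 72 h, tested at 1 uM; a higher number here means more inhibition of growth at the concentration tested, a lower number less inhibition of growth: compound 1 gives 16.2%. Compound 2 `Nc1ccc(NC(=O)C2(C(=O)Nc3ccc(F)cc3)CC2)cc1F` gives 21.7% in this assay, which sits within the scatter of the value for compound 1, so no order between the two can be read. Compound 3 `CN(C)C(=O)c1cc2cnc(Nc3ccc(NC(=O)C4(C(=O)Nc5ccc(F)cc5)CC4)cc3)nc2n1C1CCCC1` has not yet been measured; it differs from compound 1 by 4-fluorophenyl in place of 3-chlorophenyl on an amide-type nitrogen. Among the compounds with values here, no measured pair shows this single change on its own, so the direction is open. The step expected from this change is small, a number 1.8 percentage points higher from compound 1 to compound 3 (within the scatter), not beyond the scatter. In this assay compound 3 is expected to give 18%, in a range from 5% to 35%.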

Compound 3, percent growth inhibition at one concentration: 36.5%
Beside the measured number, compound 3's estimate is 18.5 percentage points below it; measured number outside the range, above it.
By their numbers in this assay, from the lowest: compounds 1 and 2 (each within the scatter of the next); then compound 3.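

Within the data shown here, on the amide-type nitrogen, 4-fluorophenyl in place of 3-chlorophenyl gives the first single-place step in this assay: a number 20.3 percentage points higher from compound 1 to compound 3 (beyond the scatter). With the rest of compound 1 held fixed, the group on this nitrogen therefore changes growth inhibition, although the two groups have the same heavy-atom count. No measured property bears on the reason for this step.

Going by these compounds, the halogen and its ring position change together in this pair, so their separate contributions remain open. Also open, on these data alone, is how unsubstituted phenyl, 3-fluorophenyl or 4-chlorophenyl would read on this nitrogen.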